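Fluoro on the phenyl of compound 1

A few compounds are considered here, and "the series" means these few. Any claim that something is new, unique, unknown or untested is made for them only; others in the source may bear on it.

Measured in an ADME assay on cells (Hepatocyte, Homo sapiens) for pharmacokinetics (a higher number here means faster removal of the compound, a lower number slower removal), for three compounds:
- compound 1 `Cc1cc(NC(=O)Cn2nnc(-c3ccccc3)n2)n(C2CCCCC2)n1` at 18.9 mL/min/kg
- compound 2 `Cc1cc(NC(=O)Cn2nnc(-c3ccccc3)n2)n(C2CCS(=O)(=O)C2)n1` at < 10.7 mL/min/kg which is a limit of the assay
- compound 3 `Cc1cc(NC(=O)Cn2nnc(-c3ccccc3)n2)n(CC2CCCCC2)n1` at 20.4 mL/min/kg

For the measured compounds named here, compound 1 stands level with the only other compound that has a number, the step being a 1.1-fold higher number from compound 1 to compound 3 (0.03 log units; within the scatter) here. Compound 4 `Cc1cc(NC(=O)Cn2nnc(-c3cccc(F)c3)n2)n(C2CCCCC2)n1` carries fluoro in place of hydrogen on an aromatic carbon so that phenyl becomes 3-fluorophenyl. The other measured step is an at least 1.7-fold lower number from compound 1 to compound 2 (0.24 log units; that floor lies within the scatter) and it also changes the group on an aromatic nitrogen. Neither step touches the phenyl, so both are only weak guides. No step beyond the scatter is expected in this assay and the estimated step is a 1.0-fold higher number from compound 1 to compound 4 (0.00 log units; within the scatter) as expected for now. For compound 4 the estimated clearance is 19 mL/min/kg with an expected range of 11 mL/min/kg to 32 mL/min/kg until measured.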

Compound 4, clearance: 17.8 mL/min/kg
Compound 4: the middle estimate sits 1.1-fold (0.03 log units) above what was measured, and the stated range covers the measured number.
By their numbers in this assay, from the lowest: compounds 4, 1 and 3 (each within the scatter of the next). At a limit, below all of these: compound 2.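

In this assay 3-fluorophenyl in place of phenyl gives a 1.1-fold lower number from compound 1 to compound 4 (0.03 log units; within the scatter) and is the first step shown on this ring rather than on the group on the aromatic nitrogen. Fluoro at this place, on the six-membered aromatic ring of carbon only, therefore leaves compound 4 within the scatter of compound 1. No measurement shown speaks to the reason for this step. Still open, as far as these compounds go, is whether an amine, a methoxy group or a nitrile at the same place would give a step beyond the scatter. Also open, from the compounds shown here alone, is whether fluoro would behave alike on compound 2, whose value is a limit.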